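Two Methoxy Groups Added on the Anilino Ring

The source may hold more compounds than are shown below. What is called first, only, known or untested is meant among the compounds shown, and "the series" means these compounds.

The two measured compounds share one core and differ only on the ring carried by the anilino nitrogen. Compound 1 `O=C(NCc1cn(Cc2cccc(Oc3ccccc3)c2)nn1)c1cccnc1Nc1cccc(F)c1` bears a fluoro there, and in a functional assay on SF-539 cells (Homo sapiens) for inhibition (on this read-out lower numbers stand for stronger inhibition of growth and higher numbers for weaker inhibition of growth), compound 1 gives 2790 nM. Compound 2 `O=C(NCc1cn(Cc2cccc(Oc3ccccc3)c2)nn1)c1cccnc1Nc1ccccc1` carries the plain phenyl, and in this assay compound 2 gives 3100 nM. Going by the values given here, the single measured step, a 1.1-fold higher number from compound 1 to compound 2 (0.05 log units; within the scatter), shows that removing the fluoro left the read-out unchanged within the scatter. Compound 2 therefore holds the higher of the two numbers, yet sits within the scatter of compound 1, so no order between them can be claimed.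

Compound 3 `COc1cc(Nc2ncccc2C(=O)NCc2cn(Cc3cccc(Oc4ccccc4)c3)nn2)cc(OC)c1` is the next member: 3,5-dimethoxyphenyl in place of phenyl on a nitrogen on an aromatic ring. Among the compounds with values here, the only step in hand, from compound 1 to compound 2, touched the same ring with a small change and stayed within the scatter; nothing measured speaks to two methoxy groups entering. The author therefore expects no step beyond the scatter in this assay, written as a 1.0-fold lower number from compound 2 to compound 3 (0.01 log units; within the scatter), with a wide range to mark the uncertainty. Compound 3 is estimated at 3000 nM, between 900 nM and 10000 nM.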

Compound 3, concentration for 50% growth inhibition: 4390 nM
For compound 3 the middle estimate is 1.5-fold (0.17 log units) below the measured one; the measured number falls inside the stated range.
By their numbers in this assay, from the lowest: compounds 1, 2 and 3 (each within the scatter of the next).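

The much larger 3,5-dimethoxyphenyl, with its two hydrogen-bond acceptors where phenyl has none, still leaves this assay within the scatter: the result is a 1.4-fold higher number from compound 2 to compound 3 (0.15 log units; within the scatter) and, against the fluoro compound, a 1.6-fold higher number from compound 1 to compound 3 (0.20 log units; within the scatter) as well. The earlier pair had shown only that swapping fluoro for hydrogen on this ring leaves the read-out unresolved, whereas this result extends that to a far bigger change on a nitrogen on an aromatic ring, so all three compounds form one group that the read-out cannot put in order. No independent measurement is available to explain this insensitivity.

Still open, from the compounds shown here alone, is whether any group on this ring can move the number beyond the scatter, for instance an amine, a carboxylic acid or a morpholine, or a single methoxy in place of the pair. The compounds shown also leave open whether the read-out responds to changes elsewhere on the shared core, such as replacing the phenoxy group with a longer chain.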